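The source may report more compounds than this note shows. Statements on the series, on what has been measured and on what is new or still open speak of the compounds shown alone.

Working notes on the series; numbers are from a functional assay for agonist activity at Free fatty acid receptor 1 (Homo sapiens), read by FLIPR, in the presence of a further agent that is not named here; on this read-out higher numbers stand for an effect only at larger amounts of compound and lower numbers for an effect already at smaller amounts:

compound 1 `O=C1NC(=O)C(Cc2ccc(Oc3ccccc3)cc2)S1` gives 307 nM
compound 2 `O=C1NC(=O)C(Cc2ccc(OCc3ccccc3)cc2)S1` gives 6180 nM

Within the data shown here, compound 2 stands highest of the two numbers in this assay; its nearest neighbour is compound 1, and the only measured step is a 20-fold higher number from compound 1 to compound 2 (1.30 log units; beyond the scatter). Compound 3 `Cc1cccc(Oc2ccc(CC3SC(=O)NC3=O)cc2)n1` differs from compound 2 by 6-methylpyridin-2-yl in place of benzyl on an oxygen on an aromatic ring. Among the measured compounds shown here, the one step that bears on this change is the large one from compound 1 to compound 2, in which the six-membered aromatic ring placed directly on the oxygen was exchanged for benzyl. For the measured compounds named here, compound 3 reverses that kind of exchange, though the entering ring carries a nitrogen and a methyl that no measured compound has, so the size of the return is uncertain. A step back towards the number of compound 1 is expected. Compound 3 is expected to give 500 nM in this assay, within 150 nM to 2000 nM, which means an expected step of a 12-fold lower number from compound 2 to compound 3 (1.09 log units; beyond the scatter).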

Compound 3, half-maximal effective concentration: 2620 nM
Compound 3: the middle estimate sits 5.2-fold (0.72 log units) below what was measured; the whole stated range lies below it.
By their numbers in this assay, from the lowest: compound 1; then compound 3; then compound 2.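

In this assay the change shows a 2.4-fold lower number from compound 2 to compound 3 (0.37 log units; beyond the scatter) and so 6-methylpyridin-2-yl gives a lower number than benzyl at this place, yet the same ring falls short of phenyl with an 8.5-fold higher number from compound 1 to compound 3 (0.93 log units; beyond the scatter) as its step. A six-membered aromatic ring set directly on the oxygen is thus not enough by itself to reach the number of compound 1, and the position separates two such rings as well as separating them from benzyl. Nothing on hand explains the remaining gap.

Going by these compounds, the nitrogen and the methyl enter together, so their separate shares stay open, and a plain pyridin-2-yl or a methyl-bearing phenyl on the oxygen would divide them. On these data alone, whether a carboxylic acid or an amine on this ring is accepted also remains open.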